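Swapping a halogen for methoxy on a shared aminothiophene core

The source may report more compounds than this note shows. Statements on the series, on what has been measured and on what is new or still open speak of the compounds shown alone.

Three compounds share one core and differ only in the group at one position of the phenyl ring attached to it. Compound 1 `Nc1scc(-c2ccc(F)cc2)c1C(=O)c1ccccc1` carries fluoro and gives 60% in a functional assay on CHO cells for agonist activity at adenosine receptor A1 (Homo sapiens), read by fluorescence and ERK phosphorylation, with stated times of 30 min and 1.5 h, tested at 10 uM; on this read-out lower numbers stand for a weaker effect and higher numbers for a stronger effect at the one concentration tested. Compound 2 `Nc1scc(-c2ccc(Br)cc2)c1C(=O)c1ccccc1` carries bromo and in this assay gives 49%, while compound 3 `Nc1scc(-c2ccc(I)cc2)c1C(=O)c1ccccc1` carries iodo and in this assay gives 50%. Within this set compound 3 sits second of the three numbers, close to compound 2 and only somewhat under compound 1: a number 1 percentage points higher from compound 2 to compound 3 (within the scatter), and a number 10 percentage points lower from compound 1 to compound 3 (within the scatter).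

Compound 4 `COc1ccc(-c2csc(N)c2C(=O)c2ccccc2)cc1` is not yet measured. It differs from compound 3 as follows: methoxy in place of iodo on an aromatic carbon.

The measured steps all swap one halogen for another and were small: a number 11 percentage points lower from compound 1 to compound 2 (beyond the scatter), a number 10 percentage points lower from compound 1 to compound 3 (within the scatter), a number 1 percentage points higher from compound 2 to compound 3 (within the scatter). For the measured compounds named here, none of them introduces a methoxy group, so there is no direct precedent. Given that three different groups at this position gave numbers within a narrow band, the expectation for compound 4 is a change of little or no size beyond the scatter, estimated as a number 2 percentage points higher from compound 3 to compound 4 (within the scatter). For compound 4 the estimated value in this assay is 52%, with a range from 30% to 75%.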

Compound 4, a percentage reported as activity, at one concentration (the size of the read-out at that concentration, not a potency): 52%
Beside the measured number, compound 4's estimate shows no gap at the digits printed; the measured number falls inside the stated range.
By their numbers in this assay, from the lowest: compounds 2, 3, 4 and 1 (each within the scatter of the next, the first and the last beyond it).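

Methoxy is the first group at this position that is not a halogen: it brings two heavy atoms in place of one, and a hydrogen-bond acceptor where iodo has none, yet in this assay the swap gives a number 2 percentage points higher from compound 3 to compound 4 (within the scatter). The comparisons with the other two halogens read the same way, with a number 3 percentage points higher from compound 2 to compound 4 (within the scatter) and a number 8 percentage points lower from compound 1 to compound 4 (within the scatter), so among these four compounds a halogen is not needed at this position for the read-out to stay in this range. Nothing available here explains why such different groups give such similar numbers.

The compounds shown leave open whether the same range would hold for an amine, a carboxylic acid or a longer chain such as butoxy at this position. Each number also describes the effect at a single concentration, so whether these compounds differ in potency remains an open question, as does the effect of placing methoxy elsewhere on the same ring.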